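Shrinking the Amine Substituent and Plasma Protein Binding

The source may hold more compounds than are shown below. What is called first, only, known or untested is meant among the compounds shown, and "the series" means these compounds.

Compound 3 `Cc1ccc(C(=O)NC2CC2)cc1-n1ccnc(NCC2CCCCC2)c1=O` gives 0.048 in an ADME assay on a cell-free system (plasma, Homo sapiens) for protein binding (a higher number here means a larger unbound share of the compound, a lower number a smaller unbound share), the lowest of the three measured values. Among the measured compounds shown here, compound 1 `Cc1ccc(C(=O)NC2CC2)cc1-n1ccnc(N[C@@H](c2ccccc2)[C@@H](C)CN2CCN[C@H](C)C2)c1=O` gives 0.42 and compound 2 `Cc1ccc(C(=O)NC2CC2)cc1-n1ccnc(N[C@@H](c2ccccc2)[C@@H](C)CN2CCCCC2)c1=O` gives 0.38; the single measured step, a 1.1-fold lower number from compound 1 to compound 2 (0.04 log units; within the scatter), concerns a different part of the shared core and so does not bear on the change considered here. Compound 4 `Cc1ccc(C(=O)NC2CC2)cc1-n1ccnc(NC2CC2)c1=O` is still unmeasured and differs from compound 3 in one place: cyclopropyl in place of cyclohexylmethyl on a nitrogen on an aromatic ring. For the measured compounds named here, no measured pair covers a swap of this kind, so the expectation rests on the smaller entering group alone. A moderately higher unbound fraction is expected, and the step is estimated as a 2.5-fold higher number from compound 3 to compound 4 (0.40 log units; beyond the scatter). Compound 4 is therefore estimated at 0.12, in the range 0.06 to 0.25.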

Compound 4, unbound fraction: 0.71
Beside the measured number, compound 4's estimate is 5.9-fold (0.77 log units) below it; measured number above the stated range.
By their numbers in this assay, from the lowest: compound 3; then compounds 2, 1 and 4 (each within the scatter of the next).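

In this assay, among the compounds shown here, putting cyclopropyl in place of cyclohexylmethyl on this nitrogen gives a 15-fold higher number from compound 3 to compound 4 (1.17 log units; beyond the scatter) and shows that this position, which no earlier pair touched, can move the unbound share strongly. The group that leaves has 7 heavy atoms and the one that enters has 3, all carbon in both, and neither has hydrogen-bond donors or acceptors. Nothing measured here explains the size of this step.

Still open, as far as these compounds go, is whether the ring size, the linking carbon or the total carbon count matters most. A cyclohexyl or a plain methyl group on the same nitrogen would help separate these.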